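From pyridin-3-yl to 2-chlorophenyl on the amide carbonyl

This account rests on a few compounds, and the source may have more. Where it says the series, first, only, none or still open, it means among the compounds named here.

Measured in a functional assay on SK-BR-3 cells (Homo sapiens) for antiproliferative activity, read by MTT assay, with a stated time of 72 h; a higher number here means a weaker inhibitor, a lower number a stronger inhibitor:
compound 1, `CCN1CCN(c2cc(C)c3cc(NC(=O)c4ccccc4C)ccc3n2)CC1`: 29200 nM
compound 2, `CCN1CCN(c2cc(C)c3cc(NC(=O)c4ccc5ccccc5n4)ccc3n2)CC1`: 3760 nM
compound 3, `CCN1CCN(c2cc(C)c3cc(NC(=O)c4cccnc4)ccc3n2)CC1`: 10600 nM

Compound 3 stands second highest of these three numbers: the step of a 2.8-fold higher number from compound 2 to compound 3 (0.45 log units; beyond the scatter) separates it from the lowest, while a 2.8-fold lower number from compound 1 to compound 3 (0.44 log units; beyond the scatter) separates it from the highest.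

Compound 4, `CCN1CCN(c2cc(C)c3cc(NC(=O)c4ccccc4Cl)ccc3n2)CC1`, differs from compound 3 by 2-chlorophenyl in place of pyridin-3-yl on a carbonyl carbon. The step that bears on it is a 2.8-fold lower number from compound 1 to compound 3 (0.44 log units; beyond the scatter), where a pyridin-3-yl replaced an ortho-substituted phenyl and the number fell modestly; the present change runs the other way, bringing back an ortho-substituted phenyl. Compound 4 is therefore expected to move toward compound 1, with a modest rise, a 2.1-fold higher number from compound 3 to compound 4 (0.32 log units; beyond the scatter). Compound 4 is estimated at 22000 nM, with a range from 8000 nM to 60000 nM.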

Compound 4, half-maximal inhibitory concentration: > 50000 nM
Compound 4 ended at the assay's limit; the forecaster's own chance of this, stated with the estimate: 10%; at least 2.2-fold (0.35 log units) between middle value and limit.
By their numbers in this assay, from the lowest: compound 2; then compound 3; then compound 1. At a limit, above all of these: compound 4.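

In this assay, compound 4 stands at a limit of the assay and not at a number: the limit of > 50000 nM in this assay, at which 1 of the 4 values shown sits. On the amide carbonyl, 2-chlorophenyl gives way to both pyridin-3-yl and quinolin-2-yl, with an at least 4.7-fold higher number from compound 3 to compound 4 (0.67 log units; beyond the scatter) and an at least 13-fold higher number from compound 2 to compound 4 (1.12 log units; beyond the scatter). Against 2-methylphenyl the result is an at least 1.7-fold higher number from compound 1 to compound 4 (0.23 log units; that floor lies within the scatter), which settles no order between chloro and methyl. The compounds shown leave open where a plain phenyl or a phenyl carrying an amine would fall, and how far compound 4 lies beyond its limit.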